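The source may report more compounds than this note shows. Statements on the series, on what has been measured and on what is new or still open speak of the compounds shown alone.

In an ADME assay on liver (Homo sapiens) for metabolic stability, read by LC-MS, using microsomes and NADPH, with a stated time of 40 min, tested at 1 uM (a higher number here means faster removal of the compound, a lower number slower removal), compound 1 `COc1cc(C(F)(F)F)ccc1-c1cccc2cc(S(=O)(=O)Nc3ccncn3)ccc12` is reported only as a limit, < 14 mL.min-1.g-1. Compound 2 `COc1cc(C(F)(F)F)ccc1-c1cccc2cc(S(=O)(=O)Nc3ccccn3)ccc12` gives 16 mL.min-1.g-1, and compound 3 `COc1cc(C(F)(F)F)ccc1-c1cccc2cc(S(=O)(=O)Nc3cncs3)ccc12` gives 46 mL.min-1.g-1, the higher of the two actual numbers. Compound 4 `COc1cc(C(F)(F)F)ccc1-c1cccc2cc(S(=O)(=O)Nc3cscn3)ccc12` has the same atoms as compound 3, joined differently: 1,3-thiazol-4-yl in place of 1,3-thiazol-5-yl on a sulfonamide nitrogen, with 1,3-thiazol-4-yl in place of 1,3-thiazol-5-yl on a sulfonamide nitrogen. Other ring changes at this place gave a 2.9-fold higher number from compound 2 to compound 3 (0.46 log units; beyond the scatter) and an at least 3.2-fold higher number from compound 1 to compound 3 (0.51 log units; beyond the scatter). Since compound 3 stands at the top with 46 mL.min-1.g-1, a move towards a lower number is expected, but a smaller one than those steps. The expected step is a 1.7-fold lower number from compound 3 to compound 4 (0.23 log units; within the scatter). The estimate for compound 4 is 27 mL.min-1.g-1, with a range of 12 mL.min-1.g-1 to 60 mL.min-1.g-1.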

Compound 4, intrinsic clearance in microsomes: < 14 mL.min-1.g-1
Compound 4 gave a limit, no number (the forecaster's own chance of this, stated with the estimate: 10%); middle value at least 1.9-fold (0.28 log units) from the limit.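

In this assay, the change from 1,3-thiazol-5-yl to 1,3-thiazol-4-yl on a sulfonamide nitrogen keeps the same atoms yet gives an at least 3.2-fold lower number from compound 3 to compound 4 (0.51 log units; beyond the scatter), so at this position the way the ring is joined matters, not only which ring is present. Against the pyridin-2-yl compound the result is an at least 1.1-fold lower number from compound 2 to compound 4 (0.05 log units; that floor lies within the scatter), which sets no order between those two. The step between compound 1 and compound 4 cannot be read, since both sit at a limit: the limit of < 14 mL.min-1.g-1 in this assay, at which 2 of the 4 values shown sit.

As far as these compounds go, whether an oxazole or an imidazole ring at this nitrogen would show the same dependence on how it is joined stays open. Also open, from the compounds shown here alone, is whether a methyl group on the 1,3-thiazol-4-yl ring would change the result.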